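The source may hold more compounds than are shown below. What is called first, only, known or untested is meant among the compounds shown, and "the series" means these compounds.

Compound 2 `COc1cc(-c2nn(-c3cccc(NC(=O)Nc4ccc(Cl)c(C(F)(F)F)c4)c3)cc2-c2ccncc2)ccc1Cl` shows the lowest of the two numbers in a functional assay on CAKI-1 cells (Homo sapiens) for inhibition, read by sulforhodamine B assay, with a stated time of 48 h (a higher number here means a weaker inhibitor of growth, a lower number a stronger inhibitor of growth), where compound 2 gives 992 nM; its nearest neighbour is compound 1 `COc1cc(-c2nn(-c3cccc(NC(=O)Nc4cccc(C(F)(F)F)c4)c3)cc2-c2ccncc2)ccc1Cl`, which in this assay gives 1030 nM. Among the measured compounds shown here, the only measured step, a 1.0-fold lower number from compound 1 to compound 2 (0.02 log units; within the scatter), does not touch the urea. For the measured compounds named here, compound 3 `COc1cc(-c2nn(-c3cccc(NC(=O)c4ccccc4)c3)cc2-c2ccncc2)ccc1Cl` differs from compound 2 by phenyl in place of (4-chloro-3-(trifluoromethyl)phenyl)amino on a carbonyl carbon, a change for which no measured step exists. Because a 1.0-fold lower number from compound 1 to compound 2 (0.02 log units; within the scatter) offers no guidance on removing that group, the expected step of a 3.0-fold higher number from compound 2 to compound 3 (0.48 log units; beyond the scatter) is uncertain and leans toward a higher number. Compound 3 is estimated at 3000 nM, within 800 nM to 12000 nM.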

Compound 3, concentration for 50% growth inhibition: 1160 nM
Beside the measured number, compound 3's estimate is 2.6-fold (0.41 log units) above it, within the range that was stated.
By their numbers in this assay, from the lowest: compounds 2, 1 and 3 (each within the scatter of the next).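

Phenyl in place of (4-chloro-3-(trifluoromethyl)phenyl)amino on the carbonyl carbon gives a 1.2-fold higher number from compound 2 to compound 3 (0.07 log units; within the scatter) in this assay and phenyl in place of (3-(trifluoromethyl)phenyl)amino gives a 1.1-fold higher number from compound 1 to compound 3 (0.05 log units; within the scatter) in the same assay. At this position, then, the whole arylamino group, including its hydrogen-bond donor, can give way to phenyl with no change beyond the scatter. No supporting evidence accounts for this result. The compounds shown leave open whether a methyl group on this carbonyl carbon, or a carboxylic acid on the entering phenyl, would move the number beyond the scatter. They also leave open how much of the growth inhibition rests on the shared core.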